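A Methyl Added to a Weak Cell-Growth Inhibitor

A few compounds are considered here, and "the series" means these few. Any claim that something is new, unique, unknown or untested is made for them only; others in the source may bear on it.

Of the compounds shown here, two have so far been measured in a functional assay on RS4-11 cells (Homo sapiens) for inhibition, read by CCK-8 assay, with a stated time of 48 h; a higher number here means a weaker inhibitor, a lower number a stronger inhibitor. Compound 1, `COc1ccc(Oc2ccccc2-c2ccsc2S(=O)(=O)NCCNC(=S)Nc2cc(C(F)(F)F)cc(C(F)(F)F)c2)cc1OC`, gives 3300 nM. Compound 2, `O=S(=O)(NCCNC(=S)Nc1cc(C(F)(F)F)cc(C(F)(F)F)c1)c1sccc1-c1ccccc1Oc1ccc(O)c(O)c1`, gives 4800 nM. Between them, a 1.5-fold higher number from compound 1 to compound 2 (0.16 log units; within the scatter), so compound 2 holds the higher of the two numbers, yet its gap to compound 1 lies within the scatter and no order between the two can be claimed.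

Compound 3, `Cc1ccc(-c2ccsc2S(=O)(=O)NCCNC(=S)Nc2cc(C(F)(F)F)cc(C(F)(F)F)c2)c(Oc2ccc(O)c(O)c2)c1`, is the next compound to be measured in this assay. For the measured compounds named here, its single change from compound 2 is methyl in place of hydrogen on an aromatic carbon; the new group sits on an aromatic carbon of a six-membered aromatic ring of carbon only, meta to a 3,4-dihydroxyphenoxy group and para to a large group.

Going by the values given here, no measured step touches this kind of change. Among the compounds with values here, the one known step alters groups on the oxygen-linked ring, not this carbon, and stayed within the scatter. There is thus no ground for expecting a move beyond the scatter in this assay. Compound 3 is therefore expected to give about 4800 nM, with a range from 2000 nM to 11000 nM, an expected step of no change at the digits printed from compound 2 to compound 3 (within the scatter).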

Compound 3, half-maximal inhibitory concentration: 4800 nM
Estimate against measurement, compound 3: no gap at the digits printed; measured number inside the range.
By their numbers in this assay, from the lowest: compounds 1, 2 and 3 (each within the scatter of the next).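

In this assay, putting a methyl in place of hydrogen on this aromatic carbon, meta to a 3,4-dihydroxyphenoxy group and para to a large group, gives no change at the digits printed from compound 2 to compound 3 (within the scatter). For the compounds shown here, the only earlier step altered groups on the oxygen-linked ring, so this is the first reading at this carbon, and it shows that one added carbon here leaves the number where it was. Nothing available explains why the number holds, and no outside measurement on these compounds bears on the result.

Going by these compounds alone, a methyl is only one small group, so what an amine, a carboxylic acid or a longer chain on this same carbon would do in this assay remains open. Within the data shown here, it is also open whether the methyl would behave the same way with the 3,4-dimethoxyphenyl group of compound 1, and, with all three compounds lying within the scatter of their neighbours, the series so far points to no change that moves the number in either direction.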